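Compound 4: A (Piperidin-1-yl)carbonyl Analogue of Compound 1

A few compounds are considered here, and "the series" means these few. Any claim that something is new, unique, unknown or untested is made for them only; others in the source may bear on it.

Compound 1 `COc1ccc(-c2nc(/N=C(\N)NC3CCCCC3)sc2-c2ccc(OC)cc2)cc1` was examined in a functional assay (aorta) with Rattus norvegicus as the target; on this read-out higher numbers stand for an effect only at larger amounts of compound and lower numbers for an effect already at smaller amounts. In this assay compound 1 gives > 100 uM, which is a limit of the assay and not a number. Two companions help to place it. Compound 2 `COc1ccc(-c2nc(C(=O)N(C)C)sc2-c2ccc(OC)cc2)cc1` gives 3 uM in this assay. Compound 3 `COc1ccc(-c2nc(C(=O)N=C(N)N)sc2-c2ccc(OC)cc2)cc1` gives > 100 uM, again a limit of the assay. Across the three, the limit of > 100 uM in this assay, at which 2 of the 3 values shown sit, marks where two of the values sit. The measured steps are an at least 33-fold lower number from compound 1 to compound 2 (1.52 log units; beyond the scatter) and an at least 33-fold higher number from compound 2 to compound 3 (1.52 log units; beyond the scatter); for compound 1 and compound 3 both values are limits, so that pair shows nothing about size.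

Compound 4 `COc1ccc(-c2nc(C(=O)N3CCCCC3)sc2-c2ccc(OC)cc2)cc1` differs from compound 1 in one place: a group of 8 heavy atoms (6 carbon, 1 nitrogen, 1 oxygen; one six-membered non-aromatic ring with 1 hetero atom) in place of a group of 10 heavy atoms (7 carbon, 3 nitrogen; one six-membered non-aromatic ring of carbon only), on an aromatic carbon. Within the data shown here, the change most like it is the one from compound 1 to compound 2, where a carbonyl carrying a nitrogen with two carbon substituents also replaced the group of 10 heavy atoms, and that step was large and downward. The step toward compound 4 is therefore expected to be an at least 33-fold lower number from compound 1 to compound 4 (1.52 log units; beyond the scatter). Compound 4 is estimated to give 3 uM in this assay, within a range from 0.8 uM to 15 uM.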

Compound 4, concentration for half-maximal effect: 11 uM
Compound 4: middle estimate off by 3.7-fold (0.56 log units), on the low side; measured number inside the range.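

In this assay, (piperidin-1-yl)carbonyl on this aromatic carbon gives a readable value, unlike the group it replaces in compound 1 (an at least 9.0-fold lower number from compound 1 to compound 4 (0.95 log units; beyond the scatter)) and the group on the carbonyl in compound 3 (an at least 9.0-fold lower number from compound 3 to compound 4 (0.95 log units; beyond the scatter)). Both steps start from a limit of the assay, so they show only the smallest possible size: the limit of > 100 uM in this assay, at which 2 of the 4 values shown sit. Compound 2 is therefore no longer the only readable amide at this position, and the group on the carbonyl still matters, since piperidin-1-yl in place of dimethylamino gives a modest rise beyond the scatter (a 3.7-fold higher number from compound 2 to compound 4 (0.56 log units; beyond the scatter)).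

The compounds shown leave open what morpholin-4-yl or a smaller group such as methylamino would give on this carbonyl. They also leave open how a carboxylic acid at this place would read.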